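Chloro substitution on the shared core: compound 1 to compound 4

This account rests on a few compounds, and the source may have more. Where it says the series, first, only, none or still open, it means among the compounds named here.

Measured compounds:
compound 1 `O=S(=O)(c1cc2ccccc2cn1)n1cc(C2=CCNCC2)c2ccccc21` gives 12 nM
compound 2 `O=S(=O)(c1cccc2ncccc12)n1cc(C2=CCNCC2)c2cc(Cl)ccc21` gives 11 nM
compound 3 `COc1ccc2c(c1)c(C1=CCNCC1)cn2S(=O)(=O)c1cc2ccccc2cn1` gives 6 nM

In an assay on HEK293 cells for displacement of a labelled ligand from 5-hydroxytryptamine receptor 6 (Homo sapiens), read by scintillation counting (a lower number here means a stronger inhibitor, a higher number a weaker inhibitor), compound 1 sits at the highest of the three numbers, but its neighbours lie close: compound 2 carries a chloro group on a different sulfonyl isomer and shows a number within the scatter of compound 1, and the step of a 2.0-fold lower number from compound 1 to compound 3 (0.30 log units; within the scatter) is also within the scatter. Compound 4 `O=S(=O)(c1cc2ccccc2cn1)n1cc(C2=CCNCC2)c2ccc(Cl)cc21` differs from compound 1 by chloro in place of hydrogen on an aromatic carbon, on an aromatic carbon of a six-membered aromatic ring of carbon only, part of a fused system of two rings. Because the change a 2.0-fold lower number from compound 1 to compound 3 (0.30 log units; within the scatter) and the value of compound 2 11 nM show no movement beyond the scatter, no step beyond the scatter is expected here. Compound 4 is estimated at 9 nM, with a range from 4 nM to 25 nM, an expected step of a 1.3-fold lower number from compound 1 to compound 4 (0.12 log units; within the scatter).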

Compound 4, inhibition constant: 102 nM
For compound 4 the middle estimate is 11-fold (1.05 log units) below the measured one; the measured number lies above the stated range.
By their numbers in this assay, from the lowest: compounds 3, 2 and 1 (each within the scatter of the next); then compound 4.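

Chloro in place of hydrogen on this aromatic carbon brings an 8.5-fold higher number from compound 1 to compound 4 (0.93 log units; beyond the scatter) in this assay and is the only step shown that lies beyond the scatter. The other step on this core, methoxy in place of hydrogen, gives a 2.0-fold lower number from compound 1 to compound 3 (0.30 log units; within the scatter) and stays within it. This shows that one added heavy atom on the carbon-only ring of the shared core can move the number. Nothing available explains the rise. Going by these compounds, what fluoro, methyl or an amine on this same carbon would give remains open, as does whether the rise is particular to chloro.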